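Removing the Chloro from the Benzylamide in a Cytotoxicity Series

A few compounds are considered here, and "the series" means these few. Any claim that something is new, unique, unknown or untested is made for them only; others in the source may bear on it.

Measured so far:
- compound 1, `O=C(CSc1nc2ccc(NC(=O)c3ccc(Cl)cc3)cc2s1)NCc1ccc(Cl)cc1`: 17800 nM
- compound 2, `CC(=O)Nc1ccc2nc(SCC(=O)NCc3ccc(Cl)cc3)sc2c1`: 6700 nM

Both numbers come from a functional assay on HepG2 cells (Homo sapiens) for cytotoxicity, read by MTT assay, with a stated time of 48 h; on this read-out higher numbers stand for weaker inhibition and lower numbers for stronger inhibition. Compound 1 holds the highest of the two numbers; its nearest neighbour is compound 2, and the step of a 2.7-fold lower number from compound 1 to compound 2 (0.42 log units; beyond the scatter) is modest but beyond the scatter.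

The next compound, compound 3 `O=C(CSc1nc2ccc(NC(=O)c3ccc(Cl)cc3)cc2s1)NCc1ccccc1`, differs from compound 1 by hydrogen in place of chloro on an aromatic carbon; the same difference, cut one bond further out, reads 4-chlorophenyl to phenyl, 4-chlorobenzyl to benzyl, (4-chlorobenzyl)amino to benzylamino. Among the measured compounds shown here, the only measured step, from compound 1 to compound 2, alters the group on a carbonyl carbon, not the benzylic ring, so no measured step bears directly on this change. The expectation therefore rests on the small size of the change alone: one chlorine leaves and a hydrogen enters. In this assay compound 3 is expected to show a step of a 1.2-fold higher number from compound 1 to compound 3 (0.09 log units; within the scatter), that is, no change beyond the scatter, with a slight lean to a higher number. The estimate for compound 3 is 22000 nM, within 8000 nM to 60000 nM.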

Compound 3, half-maximal inhibitory concentration: 25400 nM
For compound 3 the middle estimate is 1.2-fold (0.06 log units) below the measured one; the measured number falls inside the stated range.
By their numbers in this assay, from the lowest: compound 2; then compounds 1 and 3 (each within the scatter of the next).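

Among the compounds shown here, the step of a 1.4-fold higher number from compound 1 to compound 3 (0.15 log units; within the scatter) in this assay is the first reading at this position on the benzyl ring, and it lies within the scatter. For the compounds shown here, on the frame of compound 1, chloro and hydrogen on this aromatic carbon therefore cannot be told apart, whereas the change from 4-chlorophenyl to methyl on a carbonyl carbon gave a 2.7-fold lower number from compound 1 to compound 2 (0.42 log units; beyond the scatter) and remains the only step beyond the scatter. No measurement shown here bears on why the chloro can leave this ring with so little effect on the number.

From the compounds shown here alone, whether hydrogen in place of chloro reads the same way in compound 2, which carries methyl on that carbonyl carbon, stays open. Also open, going by these compounds, is whether a group of another kind on this ring carbon, such as methoxy, a carboxylic acid or a dimethylamino group, would move the number beyond the scatter, since chloro and hydrogen alone give no trend for this position.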